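A few compounds are considered here, and "the series" means these few. Any claim that something is new, unique, unknown or untested is made for them only; others in the source may bear on it.

Compound 1 `CCCCc1nnc(O)n2c(CCC)nc(C)c12`: in a functional assay for inhibition, with Homo sapiens as the target (a higher number here means a weaker inhibitor, a lower number a stronger inhibitor), compound 1 gives > 48000 nM, which is a limit of the assay and not a number.
Compound 2 `CCCc1nc(C)c2cnnc(O)n12`: in this assay compound 2 gives 56800 nM.

For the measured compounds named here, compound 2 stands on the only number the set shows; the other value is a limit. The change that leads on from it is propyl in place of hydrogen on an aromatic carbon, giving compound 3 `CCCc1nnc(O)n2c(CCC)nc(C)c12`. Going by the values given here, only one measured step bears on this: the step that the limit leaves unreadable from compound 1 to compound 2, which is the same position with butyl against hydrogen. Among the compounds with values here, its size cannot be read, since the limit of > 48000 nM in this assay, at which 1 of the 2 values shown sits, sits at the limit; it tells only that compound 1 was no stronger an inhibitor than the limit allows. Compound 3 carries a chain of intermediate length at that position, so no step beyond the scatter is expected from compound 2 in this assay, in either direction. For compound 3 the estimate in this assay is 55000 nM, between 20000 nM and 150000 nM, meaning an expected step of a 1.0-fold lower number from compound 2 to compound 3 (0.01 log units; within the scatter).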

Compound 3, half-maximal inhibitory concentration: 16000 nM
For compound 3 the middle estimate is 3.4-fold (0.54 log units) above the measured one, outside the stated range (below it).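

In this assay, the position on the aromatic carbon turns out to respond to the group it carries: propyl in place of hydrogen gives a 3.6-fold lower number from compound 2 to compound 3 (0.55 log units; beyond the scatter). The chain length there also counts, since hydrogen in place of methyl on a saturated chain carbon, three bonds along the chain from the aromatic carbon, gives an at least 3.0-fold lower number from compound 1 to compound 3 (0.47 log units; beyond the scatter), and among these compounds propyl alone brings a clear gain over both hydrogen and butyl. Compound 1 stands at a limit of the assay, so its step to compound 2 cannot be read: the limit of > 48000 nM in this assay, at which 1 of the 3 values shown sits.

With only hydrogen, propyl and butyl shown, it remains open whether ethyl or a branched chain such as isopropyl would do as well as propyl. It is equally open how an amine or a carboxylic acid on this carbon would read, and nothing shown gives a cause for the step.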